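The compounds below may be only part of what the source reports. "The series", "measured", "known", "first", "only" and "open" are said of these compounds alone.

Measured in an ADME assay on H9c2 cells (Rattus norvegicus) for cytotoxicity; a lower number here means a stronger inhibitor, a higher number a weaker inhibitor:
- Compound 1 `O=C(Nc1nc2ccc(OC(F)(F)F)cc2s1)C1CC1`: 5000 nM
- Compound 2 `CC(C)C(=O)Nc1nc2ccc(Cl)cc2s1`: > 50000 nM (a limit of the assay, not a number)

Within the data shown here, only two compounds have been tested in this assay, and just one of them has a true number. Compound 1 reads 5000 nM. Compound 2 reads > 50000 nM, which is a limit and not a number, so its place on the scale is known only from that limit.

The next compound, compound 3 `O=C(CC1CC1)Nc1nc2ccc(Cl)cc2s1`, departs from compound 2 at one place: cyclopropylmethyl in place of isopropyl on a carbonyl carbon. In words, cyclopropylmethyl stands in place of isopropyl on a carbonyl carbon. Among the measured compounds shown here, no measured pair shows a change of this kind, and compound 2 offers no exact number to start from, so the size of the step can only be judged. A modest move toward lower numbers is expected, leaving compound 3 a weak inhibitor in this assay. The expected change is an at least 1.2-fold lower number from compound 2 to compound 3 (0.09 log units; that floor lies within the scatter). For compound 3 the estimated value is 40000 nM, with an expected range from 12000 nM to 80000 nM.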

Compound 3, half-maximal inhibitory concentration: > 50000 nM
Compound 3 gave a limit, no number; the forecaster's own chance of this, stated with the estimate: 55%; at least 1.2-fold (0.09 log units) between middle value and limit.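

No step can be read from compound 2 to compound 3 in this assay, because both compounds give only a limit of the assay and not a number: the limit of > 50000 nM in this assay, at which 2 of the 3 values shown sit.

On these data alone, whether cyclopropylmethyl in place of isopropyl on a carbonyl carbon changes the value at all, and in which direction, stays open.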